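Cyclopentyl on the Nitrogen: Expected Cell Killing for Compound 4

A few compounds are considered here, and "the series" means these few. Any claim that something is new, unique, unknown or untested is made for them only; others in the source may bear on it.

Measured so far:
- compound 1, `COCC(C)n1cc(C(=O)C(=O)Nc2ccc(OC)nc2)c2ccccc21`: 12 nM
- compound 2, `CCC(C)n1cc(C(=O)C(=O)Nc2ccc(OC)nc2)c2ccccc21`: 68 nM
- compound 3, `COCC(C)(C)n1cc(C(=O)C(=O)Nc2ccc(OC)nc2)c2ccccc21`: 137 nM

These three compounds share one core and differ only in the group carried on the aromatic nitrogen. In a functional assay on FaDu cells (Homo sapiens) for cytotoxicity, read by MTT assay, with a stated time of 72 h (a lower number here means that less compound is tolerated, a higher number that more compound is tolerated), compound 3 gives 137 nM, the highest of the three numbers. Its nearest neighbour is compound 2, with a 2.0-fold higher number from compound 2 to compound 3 (0.30 log units; within the scatter), so the two cannot be told apart. Its furthest is compound 1, with an 11-fold higher number from compound 1 to compound 3 (1.06 log units; beyond the scatter).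

Compound 4, `COc1ccc(NC(=O)C(=O)c2cn(C3CCCC3)c3ccccc23)cn1`, carries a different group on that same nitrogen: cyclopentyl in place of 1-(methoxymethyl)-1-methylethyl on an aromatic nitrogen. Two earlier steps bear on this. Removing the methoxy group, a 5.7-fold higher number from compound 1 to compound 2 (0.75 log units; beyond the scatter), raised the number by a modest amount. Adding a methyl at the chain carbon bound to the nitrogen, an 11-fold higher number from compound 1 to compound 3 (1.06 log units; beyond the scatter), raised it by a large amount. Compound 4 has neither the methoxy group nor a methyl at that carbon, and the cyclopentyl group is counted as having no hydrogen-bond acceptor. The expectation is therefore a number close to that of compound 2, with a 2.0-fold lower number from compound 3 to compound 4 (0.29 log units; within the scatter) as the estimated step. Compound 4 is estimated at 70 nM, within a range from 20 nM to 250 nM.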

Compound 4, concentration lethal to 50% of the cells: 370 nM
Beside the measured number, compound 4's estimate is 5.3-fold (0.72 log units) below it; measured number above the stated range.
By their numbers in this assay, from the lowest: compound 1; then compounds 2 and 3 (each within the scatter of the next); then compound 4.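

In this assay, cyclopentyl on the aromatic nitrogen gives the highest number of the four compounds, with a 2.7-fold higher number from compound 3 to compound 4 (0.43 log units; beyond the scatter), a 5.4-fold higher number from compound 2 to compound 4 (0.74 log units; beyond the scatter) and a 31-fold higher number from compound 1 to compound 4 (1.49 log units; beyond the scatter). The step from sec-butyl to cyclopentyl shows that the absence of the methoxy group does not by itself fix the number at this position: neither group carries that oxygen, yet the ring and the open chain lie beyond the scatter of each other. No measurement shown here explains why the ring gives a higher number than any of the open-chain groups.

With only one ring among these groups, the effect of ring size remains open, and a cyclobutyl or cyclohexyl group on the same nitrogen would test it. Also open, as far as these compounds go, is whether a methoxy group on the cyclopentyl ring, or an oxygen within the ring as in tetrahydrofuranyl, would bring the number back towards that of compound 1 at 12 nM, as the methoxy-bearing chain of that compound might suggest.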